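The source may report more compounds than this note shows. Statements on the series, on what has been measured and on what is new or still open speak of the compounds shown alone.

Of the compounds shown here, three sharing one core have been tested in an ADME assay on BCBL1 cells (Homo sapiens) for cytotoxicity, with a stated time of 7 days; a lower number here means that less compound is tolerated, a higher number that more compound is tolerated. Compound 1 `Nc1nc(NC2CCCCC2)c2ncn(/C=C3/CC3(CO)CO)c2n1` carries a cyclohexylamino group on an aromatic carbon of that core. In this assay compound 1 gives > 20000 nM, which is a limit of the assay and not a number. Compound 2 `CC(C)CSc1nc(N)nc2c1ncn2/C=C1/CC1(CO)CO` has isobutylsulfanyl in place of cyclohexylamino. In this assay compound 2 gives > 20000 nM, again a limit rather than a number. Compound 3 `CCCCCOc1nc(N)nc2c1ncn2/C=C1/CC1(CO)CO` has pentyloxy in that place. In this assay compound 3 gives > 20000 nM, also a limit. Compound 3 thus stands where every measured value stands: the limit of > 20000 nM in this assay, at which 3 of the 3 values shown sit. The steps a step that the two limits leave unreadable from compound 1 to compound 2, a step that the two limits leave unreadable from compound 1 to compound 3 and a step that the two limits leave unreadable from compound 2 to compound 3 cannot be sized for that reason. Compound 4 `CCCCCCCCSc1nc(N)nc2c1ncn2/C=C1/CC1(CO)CO` is not yet measured; its change from compound 3 is octylsulfanyl in place of pentyloxy on an aromatic carbon. The measured steps that bear on this change all join values sitting at the limit, so no step beyond the scatter is expected in this assay in either direction. Compound 4 is therefore expected to give about 40000 nM, within 15000 nM to 150000 nM. The step that the limit leaves unreadable from compound 3 to compound 4 is estimated to be essentially none.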

Compound 4, half-maximal cytotoxic concentration: > 20000 nM
Compound 4 was reported as a limit (the forecaster's own chance of this, stated with the estimate: 85%); the middle value does not contradict the limit.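

Compound 4 is also reported only as a limit in this assay, so its steps from compound 1, compound 2 and compound 3 cannot be read: the limit of > 20000 nM in this assay, at which 4 of the 4 values shown sit.

The compounds shown leave open how far apart these four compounds truly lie in this assay, and whether any group at this place on the shared core would give a measurable number.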